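Methylamino for Azido: One Change on Two Cores

The source may hold more compounds than are shown below. What is called first, only, known or untested is meant among the compounds shown, and "the series" means these compounds.

Measured compounds:
compound 1 `[N-]=[N+]=Nc1nccc2c1ncn2C1O[C@H](CO)[C@@H](O)[C@H]1O` — < 5%
compound 2 `[N-]=[N+]=Nc1[nH]ccc2ncnc1-2` — < 5%
compound 3 `CNc1[nH]ccc2ncnc1-2` — < 5%

All three were tested in a functional assay on EL4 cells (Mus musculus) for inhibition, tested at 100 uM; on this read-out higher numbers stand for more inhibition at the one concentration tested (going by the name of the read-out) and lower numbers for less inhibition. For compound 1 the reading of < 5% is a limit of the assay rather than a number. For compound 2 the reading of < 5% is likewise a limit. For compound 3 the reading of < 5% is a limit as well. The change from compound 2 to compound 3 is methylamino in place of azido on an aromatic carbon; the step that the two limits leave unreadable from compound 2 to compound 3 cannot be read in size, since both ends sit at a limit (the limit of < 5% in this assay, at which 3 of the 3 values shown sit).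

Compound 4 `CNc1nccc2c1ncn2C1O[C@H](CO)[C@@H](O)[C@H]1O` has not yet been measured in this assay. It differs from compound 1 by methylamino in place of azido on an aromatic carbon, the same kind of change as that from compound 2 to compound 3. How the core of compound 1 differs from the core of compound 2 is not broken down here.

With every measured compound resting at the same limit (the limit of < 5% in this assay, at which 3 of the 3 values shown sit), compound 1 is expected to carry a step that the limit leaves unreadable from compound 1 to compound 4 to compound 4. Compound 4 is therefore estimated at 3%, between 0% and 12%, most likely again reported only as a limit.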

Compound 4, a percentage reported as inhibition, at one concentration (the size of the read-out at that concentration, not a potency): 11%
Estimate against measurement, compound 4: 8 percentage points below, and the stated range covers the measured number.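

On the core of compound 1, methylamino in place of azido gives, in this assay, a number at least 6 percentage points higher from compound 1 to compound 4 (that floor lies within the scatter), so only a floor can be stated and that floor does not establish a change beyond the scatter. The reading for compound 1, < 5%, is a limit of the assay. The same change on the core of compound 2 is a step that cannot be read, so the data neither show that the change carries from one core to the other nor show that it fails to, since both of its ends and the start of the new step rest at one limit: the limit of < 5% in this assay, at which 3 of the 4 values shown sit.

The compounds shown leave open whether a plain amino group, dimethylamino or a longer chain such as butylamino, set in the place of methylamino, would read differently on the core of compound 1. They also leave open how much of the reading of compound 4, 11%, depends on its core.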